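Replacing a sulfur-bearing chain with a fluorinated aromatic ring

The source may report more compounds than this note shows. Statements on the series, on what has been measured and on what is new or still open speak of the compounds shown alone.

Measured compounds:
Compound 1 `O=C(CC1CCCCC1)N1CCN(c2nc(=O)c3cc(C(F)(F)F)cc([N+](=O)[O-])c3s2)CC1`: 0.12 ug/mL
Compound 2 `CSCC(=O)N1CCN(c2nc(=O)c3cc(C(F)(F)F)cc([N+](=O)[O-])c3s2)CC1`: 15.2 ug/mL

Going by the values given here, in a physicochemical assay for solubility, read by HPLC (a higher number here means a more soluble compound, a lower number a less soluble compound), compound 2 stands highest of the two numbers; the only other is compound 1, and the step of a 130-fold higher number from compound 1 to compound 2 (2.10 log units; beyond the scatter) shows how far apart they lie. Compound 3 `O=C(c1ccccc1F)N1CCN(c2nc(=O)c3cc(C(F)(F)F)cc([N+](=O)[O-])c3s2)CC1` is not yet measured. It differs from compound 2 by 2-fluorophenyl in place of (methylsulfanyl)methyl on a carbonyl carbon. Among the compounds with values here, the one measured step bears on it only loosely: there, exchanging the methylsulfanyl for a carbon group changed solubility greatly. Since compound 3 also loses the methylsulfanyl chain, a drop beyond the scatter is expected, roughly a 15-fold lower number from compound 2 to compound 3 (1.18 log units; beyond the scatter). Compound 3 is therefore estimated at 1 ug/mL, within 0.2 ug/mL to 5 ug/mL.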

Compound 3, solubility: 3.1 ug/mL
Compound 3: middle estimate off by 3.1-fold (0.49 log units), on the low side; low and high end bracket the measured number.
By their numbers in this assay, from the lowest: compound 1; then compound 3; then compound 2.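

In this assay the 2-fluorophenyl group gives a 4.9-fold lower number from compound 2 to compound 3 (0.69 log units; beyond the scatter) and so lies close to neither earlier group: the other step is a 26-fold higher number from compound 1 to compound 3 (1.41 log units; beyond the scatter) and is the larger of the two. Loss of the methylsulfanyl chain therefore does not set the outcome alone, since two groups without sulfur on this carbonyl carbon lie far apart. Nothing available gives a reason for either step.

The compounds shown leave open what the fluorine contributes, as plain phenyl is not among them. As far as these compounds go, how an amine or a carboxylic acid at this place would compare also remains open.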